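The source may report more compounds than this note shows. Statements on the series, on what has been measured and on what is new or still open speak of the compounds shown alone.

The measured compounds:

Compound 1, `CC1CC/C(=N\Nc2ccccc2F)c2ncc(C(=O)O)c(=O)n21`: in a functional assay on the whole organism for inhibition, with Rattus norvegicus as the target (on this read-out higher numbers stand for an effect only at larger amounts of compound and lower numbers for an effect already at smaller amounts), compound 1 gives > 1000 umol/kg, a limit of the assay rather than a number.
Compound 2, `CC1CC/C(=N\Nc2ccccc2I)c2ncc(C(=O)O)c(=O)n21`: in this assay compound 2 gives > 1000 umol/kg, also a limit.
Compound 3, `CC1CC/C(=N\Nc2ccccc2O)c2ncc(C(=O)O)c(=O)n21`: in this assay compound 3 gives > 100 umol/kg, again a limit.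

Compound 3 therefore stands only at a limit, as do the other two values, one at the limit of > 100 umol/kg in this assay, at which 1 of the 3 values shown sits, and two at the limit of > 1000 umol/kg in this assay, at which 2 of the 3 values shown sit. The steps a step that the two limits leave unreadable from compound 1 to compound 2, a step that the two limits leave unreadable from compound 1 to compound 3 and a step that the two limits leave unreadable from compound 2 to compound 3 are all unreadable. Compound 4, `CCOc1ccccc1N/N=C1\CCC(C)n2c1ncc(C(=O)O)c2=O`, differs from compound 3 by ethyl in place of hydrogen on an oxygen on an aromatic ring. Going by the values given here, no measured step touches this oxygen, so the step that the limit leaves unreadable from compound 3 to compound 4 is expected to stay within the scatter. Compound 4 is estimated at 300 umol/kg, between 100 umol/kg and 1000 umol/kg.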

Compound 4, dose for 50% inhibition: > 1000 umol/kg
Compound 4: a limit, no number; the forecaster's own chance of this, stated with the estimate: 60%; middle value at least 3.3-fold (0.52 log units) from the limit.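

In this assay compound 4 gives > 1000 umol/kg, a limit. Its steps from compound 1, compound 2 and compound 3 therefore cannot be read. The compounds shown leave open whether changing the group on the aromatic ring changes the dose needed for inhibition.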